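A few compounds are considered here, and "the series" means these few. Any claim that something is new, unique, unknown or untested is made for them only; others in the source may bear on it.

Measured compounds in a functional assay on SNB-75 cells (Homo sapiens) for inhibition, read by sulforhodamine B assay, with a stated time of 48 h, tested at 10 uM; on this read-out lower numbers stand for less inhibition and higher numbers for more inhibition at the one concentration tested (going by the name of the read-out):
- compound 1 `Brc1cn2ccnc2c(-c2ccc3ncn(C4CCCCC4)c3c2)n1`: 21.3%
- compound 2 `COc1ccc(-c2cn3ccnc3c(-c3ccc4ncn(C5CCCCC5)c4c3)n2)cc1`: -26.3%
- compound 3 `Fc1ccc(-c2cn3ccnc3c(-c3ccc4ncn(C5CCCCC5)c4c3)n2)cc1`: 21%

Compound 3 stands second highest of the three numbers. Its nearest neighbour is compound 1, and the gap a number 0.3 percentage points lower from compound 1 to compound 3 (within the scatter) lies within the scatter, so the two read as alike. Its furthest neighbour is compound 2, separated by a number 47.3 percentage points higher from compound 2 to compound 3 (beyond the scatter), a large step beyond the scatter.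

Compound 4 `FC(F)(F)c1cccc(-c2cn3ccnc3c(-c3ccc4ncn(C5CCCCC5)c4c3)n2)c1` is not yet measured. The change from compound 3 is 3-(trifluoromethyl)phenyl in place of 4-fluorophenyl on an aromatic carbon.

Among the measured compounds shown here, two measured steps bear on swapping the group at this position. Replacing bromo by 4-fluorophenyl left the number unchanged, a number 0.3 percentage points lower from compound 1 to compound 3 (within the scatter). Replacing bromo by 4-methoxyphenyl, a number 47.6 percentage points lower from compound 1 to compound 2 (beyond the scatter), dropped it far. For the measured compounds named here, a phenyl carrying trifluoromethyl rather than fluoro or methoxy has no direct precedent in this set; a third aryl variant may sit anywhere between these two outcomes, so a step downward of modest size, possibly within the scatter, is expected in this assay, with wide uncertainty.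

The expected step is a number 11 percentage points lower from compound 3 to compound 4 (beyond the scatter). Compound 4 is therefore estimated at 10% in this assay, within a range of -22% to 36%.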

Compound 4, a percentage reported as inhibition, at one concentration (the size of the read-out at that concentration, not a potency): 4.58%
Compound 4: middle estimate off by 5.4 percentage points, on the high side, within the range that was stated.
By their numbers in this assay, from the lowest: compound 2; then compound 4; then compounds 3 and 1 (each within the scatter of the next).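

In this assay, placing 3-(trifluoromethyl)phenyl on this carbon gives a number 16.4 percentage points lower from compound 3 to compound 4 (beyond the scatter) and a number 16.7 percentage points lower from compound 1 to compound 4 (beyond the scatter), so this aryl group does not match the level shared by 4-fluorophenyl and bromo. Changing 4-methoxyphenyl to this group gives a number 30.9 percentage points higher from compound 2 to compound 4 (beyond the scatter), so compound 4 also stays well clear of compound 2. The three aryl groups therefore fall at three separate levels, and an aryl group at this position does not by itself fix the number.

Going by these compounds, the step from compound 3 changes both the substituent and where it sits on the phenyl ring, so the two changes remain unseparated, and it remains open what an unsubstituted phenyl or a phenyl carrying an amine or a carboxylic acid would give. Nothing in the data offered here accounts for the differences among these groups.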